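Replacing 3-methoxyphenyl with 3,4-difluorophenyl in a cytotoxicity series

The compounds below may be only part of what the source reports. "The series", "measured", "known", "first", "only" and "open" are said of these compounds alone.

Of the compounds shown here, three have been measured in an ADME assay on HepG2 2.2.15 cells (Homo sapiens) for cytotoxicity, read by MTT assay (a higher number here means that more compound is tolerated, a lower number that less compound is tolerated), so far. Compound 1 (`CC(=O)c1ccc(OC(=O)/C=C/c2ccc(F)cc2)cc1`) returns > 3310000 nM and this is a limit, not a number. For the measured compounds named here, compound 2 (`COc1cc(C(=O)Oc2ccc(C(C)=O)cc2)cc(OC)c1OC`) gives 1210000 nM as the only exact reading. Compound 3 (`COc1cccc(/C=C/C(=O)OC[C@H]2O[C@@H](Oc3ccc(C(C)=O)cc3)[C@H](O)[C@@H](O)[C@@H]2O)c1`) returns > 1510000 nM and this too is a limit. Going by the values given here, compound 3 therefore stands without an exact value of its own, and no two measured compounds differ in one place only.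

Compound 4 (`CC(=O)c1ccc(O[C@@H]2O[C@H](COC(=O)/C=C/c3ccc(F)c(F)c3)[C@@H](O)[C@H](O)[C@H]2O)cc1`) is related to compound 3 by the change 3,4-difluorophenyl in place of 3-methoxyphenyl on a double-bonded chain carbon bound to a double-bonded chain carbon with 3,4-difluorophenyl in place of 3-methoxyphenyl on a double-bonded chain carbon bound to a double-bonded chain carbon. Among the compounds with values here, with no measured pair to size this exchange, no step beyond the usual scatter is expected in this assay for it. The exact reading of 1210000 nM for compound 2 sets the scale of that expectation. The estimated change is a step that the limit leaves unreadable from compound 3 to compound 4 and it is expected to stay small. Compound 4 is expected at 1800000 nM with an estimated range from 700000 nM to 4500000 nM and may well return only a limit.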

Compound 4, half-maximal cytotoxic concentration: 874000 nM
Estimate against measurement, compound 4: 2.1-fold (0.31 log units) above; measured number inside the range.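

In this assay, for the compounds shown here, the exchange of 3-methoxyphenyl for 3,4-difluorophenyl on a double-bonded chain carbon bound to a double-bonded chain carbon gives the first readable step, an at least 1.7-fold lower number from compound 3 to compound 4 (0.23 log units; that floor lies within the scatter). Going by these compounds alone, compound 4, with 874000 nM, also supplies the first exact value on the core of compound 3, so that core now has a number. The full size of the step stays unknown because compound 3 returns only a limit: the limit of > 1510000 nM in this assay, at which 1 of the 4 values shown sits.

Whether a real difference beyond the scatter lies behind this floor remains open. Also open, on these data alone, is how a phenyl ring carrying an amine or a carboxylic acid would read at this position on the same core.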